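The compounds below may be only part of what the source reports. "The series", "measured", "known", "first", "only" and "open" are said of these compounds alone.

Compound 1 `CC(C)C[C@H](NC(=O)[C@@H](N)CO)B(O)O` gives 1700 nM 
Compound 2 `CCC[C@H](N)C(=O)N[C@@H](CC(C)C)B(O)O` gives 1100 nM 
Compound 3 `CC(C)C[C@H](NC(=O)[C@@H](N)[C@@H](C)O)B(O)O` gives 2500 nM 

All three numbers come from an ADME assay on FSCLL cells (Homo sapiens) for cytotoxicity, read by MTT assay, with a stated time of 24 h (a lower number here means that less compound is tolerated, a higher number that more compound is tolerated), and the question here is where the next compound falls. Two steps show the standing of the third compound: there is a 1.5-fold higher number from compound 1 to compound 3 (0.17 log units; within the scatter) and there is a 2.3-fold higher number from compound 2 to compound 3 (0.36 log units; beyond the scatter) as well. It therefore sits level with the first compound and clear of the second.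

Compound 4 `CC(C)C[C@H](NC(=O)[C@@H](N)C(C)(C)C)B(O)O` carries tert-butyl in place of 1-hydroxyethyl on a saturated chain carbon bound to an amine nitrogen and a carbonyl carbon. This change removes the hydroxy group, and the closest guide is the step at that same place, a 2.3-fold higher number from compound 2 to compound 3 (0.36 log units; beyond the scatter) which runs from a group without hydroxy to one with it. Read backwards, it points to a modest fall. The evidence is thin, though, for a 1.5-fold lower number from compound 1 to compound 2 (0.19 log units; within the scatter) also swaps hydroxy away and stays small. Within the data shown here, no tert-butyl compound has been measured yet.

The step expected in this assay is therefore a 1.7-fold lower number from compound 3 to compound 4 (0.22 log units; within the scatter) and this estimate is a small move toward a lower number. For compound 4 the estimate is 1500 nM with an expected range from 650 nM to 3500 nM around it.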

Compound 4, half-maximal cytotoxic concentration: 710 nM
Compound 4: the middle estimate sits 2.1-fold (0.32 log units) above what was measured; low and high end bracket the measured number.
By their numbers in this assay, from the lowest: compounds 4, 2, 1 and 3 (each within the scatter of the next, the first and the last beyond it).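

In this assay, tert-butyl at this saturated chain carbon gives a 3.5-fold lower number from compound 3 to compound 4 (0.55 log units; beyond the scatter) and, in place of hydroxymethyl, a 2.4-fold lower number from compound 1 to compound 4 (0.38 log units; beyond the scatter) so both hydroxy-bearing groups now stand clear of a group without hydroxy, and less compound is tolerated with tert-butyl. The two groups without hydroxy do not separate, as tert-butyl in place of propyl gives a 1.5-fold lower number from compound 2 to compound 4 (0.19 log units; within the scatter) and this suggests that branching of the carbon chain matters little here, though compound 1 and compound 2 go against a clean split by hydroxy, since they too lie within the scatter of each other. Nothing measured here accounts for these differences.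

The compounds shown leave open whether the hydroxy itself is what counts, since a 1-aminoethyl group or a methoxymethyl group at this place would test that more closely than tert-butyl does. They also leave open where a carboxylic acid or a longer chain at this place would fall, and whether the same order would hold with a group other than the one kept on the rest of the shared core.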